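The source may report more compounds than this note shows. Statements on the series, on what has been measured and on what is new or still open speak of the compounds shown alone.

Working notes on the series. Compound 1 `Cc1cccc(-n2nncc2CN2C(=O)C3(C(C#N)=C(N)Oc4c3c3nc5ccccc5nc3c3ccccc43)c3ccccc32)c1` carries a 3-methylphenyl on an aromatic nitrogen of the shared core. In a functional assay on HepG2 cells (Homo sapiens) for antiproliferative activity, read by MTT assay, with a stated time of 48 h (a lower number here means a stronger inhibitor, a higher number a weaker inhibitor), compound 1 gives only a limit, > 50000 nM. Compound 2 `N#CC1=C(N)Oc2c(c3nc4ccccc4nc3c3ccccc23)C12C(=O)N(Cc1cnnn1-c1ccc(Br)cc1)c1ccccc12` has 4-bromophenyl in place of 3-methylphenyl on that aromatic nitrogen. In this assay compound 2 likewise reaches only a limit, > 50000 nM. Compound 3 `CCOc1ccccc1-n1nncc1CN1C(=O)C2(C(C#N)=C(N)Oc3c2c2nc4ccccc4nc2c2ccccc32)c2ccccc21` carries 2-ethoxyphenyl at the same nitrogen. In this assay compound 3 also gives a limit, > 50000 nM. The steps a step that the two limits leave unreadable from compound 1 to compound 2, a step that the two limits leave unreadable from compound 1 to compound 3 and a step that the two limits leave unreadable from compound 2 to compound 3 are thus not readable in size or direction; all that is known is the limit of > 50000 nM in this assay, at which 3 of the 3 values shown sit. Compound 2 therefore stands nowhere distinct from compounds 1 and 3: only a limit is known for it.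

Compound 4 `CCOc1ccc(-n2nncc2CN2C(=O)C3(C(C#N)=C(N)Oc4c3c3nc5ccccc5nc3c3ccccc43)c3ccccc32)cc1` is to be measured in this assay. It differs from compound 2 as follows: ethoxy in place of bromo on an aromatic carbon. Among the compounds with values here, none of the measured steps on this aryl gives a readable size, so no direction can be taken from them, and the three limits give no foothold for a change. Compound 4 is therefore expected to sit near the same limit, the estimated value being 80000 nM with a range from 20000 nM to 300000 nM. The step this estimate implies, a step that the limit leaves unreadable from compound 2 to compound 4, is expected to lie within the scatter if a number is obtained at all.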

Compound 4, half-maximal inhibitory concentration: > 50000 nM
Compound 4: only a limit was reported (the forecaster's own chance of this, stated with the estimate: 85%); the middle value lies beyond the limit too.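

Compound 4 also gives only a limit, so its steps from compound 1, compound 2 and compound 3 cannot be read in size or direction, and the series offers a single shared reading: the limit of > 50000 nM in this assay, at which 4 of the 4 values shown sit.

The compounds shown leave open whether any aryl group at this nitrogen of the shared core gives a measurable value in this assay.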